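The compounds below may be only part of what the source reports. "The series", "measured", "known", "first", "only" and "open" are said of these compounds alone.

The measured compounds in a functional assay on A549 cells (Homo sapiens) for antiproliferative activity, read by MTT assay; on this read-out higher numbers stand for weaker inhibition and lower numbers for stronger inhibition:
- compound 1, `Cn1c(=O)c(=O)n(C2CCCC2)c2nc(N/N=C/c3ccccc3)ncc21`: > 100000 nM
- compound 2, `Cn1c(=O)c(=O)n(C2CCCC2)c2nc(N/N=C/c3ccc(O)c(F)c3)ncc21`: 97800 nM
- compound 3, `Cn1c(=O)c(=O)n(C2CCCC2)c2nc(N/N=C/c3cccc(Cl)c3Cl)ncc21`: 39100 nM

Compound 1 carries a plain phenyl on the carbon with a double bond to nitrogen, and its value in this assay is only a limit of the assay, not a number (the limit of > 100000 nM in this assay, at which 1 of the 3 values shown sits). Compound 4, `Cn1c(=O)c(=O)n(C2CCCC2)c2nc(N/N=C/c3ccccc3F)ncc21`, has not yet been measured. It differs from compound 1 in one place: fluoro in place of hydrogen on an aromatic carbon.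

Two measured steps start from compound 1 and alter that same phenyl. Putting 3-fluoro-4-hydroxyphenyl in its place gave an at least 1.0-fold lower number from compound 1 to compound 2 (0.00 log units; that floor lies within the scatter). Putting 2,3-dichlorophenyl in its place gave an at least 2.5-fold lower number from compound 1 to compound 3 (0.40 log units; beyond the scatter), and between the two substituted rings the step was a 2.5-fold lower number from compound 2 to compound 3 (0.40 log units; beyond the scatter). The change to compound 4 brings in a single fluoro where compound 3 brought in two chloro groups, and the step from compound 1 to compound 3, an at least 2.5-fold lower number from compound 1 to compound 3 (0.40 log units; beyond the scatter), is taken here as the outer edge of what is expected. The expected step is therefore an at least 1.2-fold lower number from compound 1 to compound 4 (0.09 log units; that floor lies within the scatter). Compound 4 is estimated at 80000 nM, with a range from 30000 nM to 200000 nM, and a fair chance remains that this assay again reports only a limit.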

Compound 4, half-maximal inhibitory concentration: 31200 nM
Compound 4: middle estimate off by 2.6-fold (0.41 log units), on the high side; low and high end bracket the measured number.
By their numbers in this assay, from the lowest: compounds 4 and 3 (each within the scatter of the next); then compound 2. At a limit, above all of these: compound 1.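

In this assay, a single fluoro on an aromatic carbon, ortho to a large group, is enough to move the plain phenyl series onto a measurable number, with an at least 3.2-fold lower number from compound 1 to compound 4 (0.50 log units; beyond the scatter); that step is only a floor, and compound 1 stands at a limit of the assay, not a number: the limit of > 100000 nM in this assay, at which 1 of the 4 values shown sits. The earlier compounds shown here left unclear whether a ring needed two halogens to reach this range, yet 2-fluorophenyl and 2,3-dichlorophenyl cannot be told apart here, with a 1.3-fold lower number from compound 3 to compound 4 (0.10 log units; within the scatter). Fluoro alone does not settle the outcome, since compound 2 also carries a fluoro and goes against any simple rule that fluoro on the ring is sufficient, with a 3.1-fold lower number from compound 2 to compound 4 (0.50 log units; beyond the scatter).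

Going by these compounds, whether this position favours fluoro in particular or accepts other small groups stays open, and a chloro, methyl or methoxy group at the same place would be needed to separate the two. How a charged group such as an amine or a carboxylic acid on this ring would behave also stays open, as the compounds shown carry only halogens and a hydroxy group there.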